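The source may hold more compounds than are shown below. What is called first, only, known or untested is meant among the compounds shown, and "the series" means these compounds.

Measured compounds:
- compound 3 `Fc1ccccc1Cn1nnc2c(NC3CC3)nc(-c3ccccc3)nc21`: 15 nM
- compound 1 `CCCNc1nc(-c2ccccc2)nc2c1nnn2Cc1ccccc1C(F)(F)F`: "not determined" (no result reported)
- compound 2 `CCCCCCNc1nc(-c2ccccc2)nc2c1nnn2Cc1ccccc1C(F)(F)F`: "not determined" (no result reported)

Going by the values given here, in an assay on Cerebral cortex for displacement of a labelled ligand from adenosine receptor A1 (Bos taurus) (a higher number here means a weaker inhibitor, a lower number a stronger inhibitor), compound 3 gives 15 nM, the only number in this set. For compound 1 and compound 2, which carry a trifluoromethyl-bearing benzyl group, no result is given in this assay, so they add nothing to the numbers.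

Compound 4 `FC(F)(F)c1ccccc1Cn1nnc2c(NC3CC3)nc(-c3ccccc3)nc21` is not yet measured. It differs from compound 3 in one place: trifluoromethyl in place of fluoro on an aromatic carbon. Among the compounds with values here, because no pair of measured compounds shows this change, the size of the step from compound 3 to compound 4 cannot be read from the data.

The expectation rests on compound 3 alone, with its value of 15 nM, and the step is estimated to stay near or within the usual scatter, a 1.5-fold higher number from compound 3 to compound 4 (0.17 log units; within the scatter), since the rest of the structure is unchanged. Compound 4 is therefore estimated at 22 nM, within a range of 6 nM to 80 nM in this assay.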

Compound 4, inhibition constant: 7.8 nM
Compound 4: the middle estimate sits 2.8-fold (0.45 log units) above what was measured; measured number inside the range.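

In this assay, replacing fluoro with trifluoromethyl on this aromatic carbon, ortho to a large group, gives a 1.9-fold lower number from compound 3 to compound 4 (0.28 log units; within the scatter). The group grows from 1 heavy atom to 4 heavy atoms here, yet the two numbers cannot be told apart, so this single pair shows that the larger group at this position leaves the measured binding intact. Nothing measured here accounts for this result.

Steps from compound 4 to compound 1 and compound 2, which carry a propyl and a hexyl chain on the amine nitrogen in place of cyclopropyl, cannot be read, so the effect of changing that group remains open. As far as these compounds go, it also remains open how a chlorine atom, a methoxy group or a nitrile would fare at the position held by fluoro and trifluoromethyl.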